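The compounds below may be only part of what the source reports. "The series", "measured", "known", "first", "only" and "open" are said of these compounds alone.

Measured so far in a functional assay on SK-OV-3 cells (Homo sapiens) for cytotoxicity, read by MTT assay, with a stated time of 48 h; on this read-out higher numbers stand for weaker inhibition and lower numbers for stronger inhibition:
compound 1 `O=C(/C=C/c1ccc2c(c1)B(O)OC2)c1cccs1`, 10400 nM
compound 2 `O=C(/C=C/c1ccc2c(c1)B(O)OC2)c1ccc(Br)cc1`, 4500 nM
compound 3 `CCOC(=O)c1ccc(C(=O)/C=C/c2ccc3c(c2)B(O)OC3)cc1`, 7100 nM

Compound 2 carries the lowest of the three numbers. The step of a 2.3-fold lower number from compound 1 to compound 2 (0.36 log units; beyond the scatter) is modest and lies beyond the scatter; the step of a 1.6-fold higher number from compound 2 to compound 3 (0.20 log units; within the scatter) lies within it, so compound 2 and compound 3 cannot be separated on this read-out.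

Compound 4 `Cc1cccc(C(=O)/C=C/c2ccc3c(c2)B(O)OC3)c1` has not yet been measured. It differs from compound 2 in one place: 3-methylphenyl in place of 4-bromophenyl on a carbonyl carbon. Both measured steps concern the same place, the aryl group on the carbonyl carbon. Thiophen-2-yl to 4-bromophenyl gave a 2.3-fold lower number from compound 1 to compound 2 (0.36 log units; beyond the scatter); bromo to ethoxycarbonyl gave a 1.6-fold higher number from compound 2 to compound 3 (0.20 log units; within the scatter). Neither change moved the number far, and the group that leaves and the group that enters in the present change have the same heavy-atom count. A step within the scatter, or at most a modest one, is therefore expected in this assay, more likely towards a higher number because compound 2 already shows the lowest value in 4500 nM. The expected step for compound 4 is a 1.3-fold higher number from compound 2 to compound 4 (0.12 log units; within the scatter). The estimate for compound 4 is 6000 nM, with an expected range from 3000 nM to 12000 nM.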

Compound 4, half-maximal inhibitory concentration: 2900 nM
Estimate against measurement, compound 4: 2.1-fold (0.32 log units) above; measured number below the stated range.
By their numbers in this assay, from the lowest: compounds 4, 2, 3 and 1 (each within the scatter of the next, the first and the last beyond it).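

In this assay, 3-methylphenyl in place of 4-bromophenyl on the carbonyl carbon gives a 1.6-fold lower number from compound 2 to compound 4 (0.19 log units; within the scatter) and leaves compound 2 and compound 4 inseparable, so bromine is not required for a number at this level: a carbon-only group with the same heavy-atom count matches it. With 3-methylphenyl in place of thiophen-2-yl, the series shows a 3.6-fold lower number from compound 1 to compound 4 (0.55 log units; beyond the scatter) and lies beyond the scatter, so compound 2 and compound 4 now give two separate readings of a phenyl group on the carbonyl carbon standing apart from the thiophen-2-yl of compound 1. The change from compound 2 to compound 4 alters both the substituent and its ring location at once, so this step cannot assign any part of the result to either one.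

Going by these compounds, whether an amine or a carboxylic acid on the phenyl ring, or a longer chain such as butyl in place of methyl, would move the number beyond the scatter stays open, as does the comparison of 4-methylphenyl with 3-methylphenyl. Nothing on hand speaks to why the numbers fall where they do.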